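The source may hold more compounds than are shown below. What is called first, only, known or untested is meant among the compounds shown, and "the series" means these compounds.

In a functional assay on HCT-116 cells (Homo sapiens), read by MTT assay, with a stated time of 3 days (on this read-out higher numbers stand for weaker inhibition and lower numbers for stronger inhibition), compound 1 (`CN(C)c1ncnc2[nH]cc(Sc3cccs3)c12`) gives 11000 nM and compound 2 (`CNc1ncnc2[nH]cc(Sc3cccs3)c12`) gives 19000 nM, so compound 2 stands within the scatter of compound 1. Compound 3 (`Nc1ncnc2[nH]cc(Sc3cccs3)c12`) differs from compound 2 by hydrogen in place of methyl on a nitrogen on an aromatic ring, which is hydrogen in place of methyl on a nitrogen on an aromatic ring. Going by the values given here, the only measured step of this kind, a 1.7-fold higher number from compound 1 to compound 2 (0.24 log units; within the scatter), stayed within the scatter, so no step beyond the scatter is expected in this assay. The expected step is a 1.1-fold higher number from compound 2 to compound 3 (0.02 log units; within the scatter). Compound 3 is estimated at 20000 nM, with an expected range from 9000 nM to 45000 nM.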

Compound 3, half-maximal inhibitory concentration: 22800 nM
Compound 3: middle estimate off by 1.1-fold (0.06 log units), on the low side, within the range that was stated.
By their numbers in this assay, from the lowest: compounds 1, 2 and 3 (each within the scatter of the next, the first and the last beyond it).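

In this assay, the change from methylamino to amino gives a 1.2-fold higher number from compound 2 to compound 3 (0.08 log units; within the scatter) and so, like the earlier loss of one methyl, stays within the scatter on its own. Across both losses, amino in place of dimethylamino gives a 2.1-fold higher number from compound 1 to compound 3 (0.32 log units; beyond the scatter) and is the first change on this aromatic carbon to pass the scatter, though only modestly.

The compounds shown leave open how a longer chain on this nitrogen, such as ethylamino, or a ring amine such as morpholine would compare. No evidence is available that explains these small differences.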